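Bile acid receptor ligands: a trifluoromethoxyphenyl swap on two cores

This account rests on a few compounds, and the source may have more. Where it says the series, first, only, none or still open, it means among the compounds named here.

Measured compounds:
Compound 1, `COC(=O)/C=C/c1cccc(N(Cc2ccc(-c3cc(Cl)ccc3OC)cc2)C(=O)C(C)C)c1`, 226 nM
Compound 2, `COC(=O)/C=C/c1cccc(N(Cc2ccc(-c3ccc(OC(F)(F)F)cc3)cc2)C(=O)C(C)C)c1`, 219 nM
Compound 3, `COC(=O)/C=C/c1cccc(N(Cc2ccc(-c3cc(Cl)ccc3OC)cc2)C(=O)C2CCCCC2)c1`, 233 nM

Three compounds were tested in an assay on isolated protein with Bile acid receptor (Homo sapiens) as the target; a higher number here means that more compound is needed for the effect, a lower number that less compound is needed. Compound 1 gives 226 nM. Compound 2 differs from it by 4-(trifluoromethoxy)phenyl in place of 5-chloro-2-methoxyphenyl on an aromatic carbon, and its value of 219 nM corresponds to a 1.0-fold lower number from compound 1 to compound 2 (0.01 log units; within the scatter). Compound 3 differs from compound 1 by cyclohexyl in place of isopropyl on a carbonyl carbon; compound 3 gives 233 nM, which is a 1.0-fold higher number from compound 1 to compound 3 (0.01 log units; within the scatter). The three values therefore lie together within the scatter of the method, and no ordering among them can be claimed.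

Compound 4, `COC(=O)/C=C/c1cccc(N(Cc2ccc(-c3ccc(OC(F)(F)F)cc3)cc2)C(=O)C2CCCCC2)c1`, has not been measured in this assay. It differs from compound 3 by 4-(trifluoromethoxy)phenyl in place of 5-chloro-2-methoxyphenyl on an aromatic carbon, which is the same change as that from compound 1 to compound 2, made on a core that carries a cyclohexyl rather than an isopropyl group on the carbonyl carbon. Because that earlier step was a 1.0-fold lower number from compound 1 to compound 2 (0.01 log units; within the scatter), compound 4 is expected to show a comparably small step, a 1.0-fold lower number from compound 3 to compound 4 (0.01 log units; within the scatter), from compound 3. Going by the values given here, on this basis, compound 4 is estimated to give about 226 nM in this assay, with a likely range from 110 nM to 460 nM, the width reflecting that only one prior example of this change is available.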

Compound 4, half-maximal effective concentration: 264 nM
Compound 4: middle estimate off by 1.2-fold (0.07 log units), on the low side; measured number inside the range.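

In this assay, placing 4-(trifluoromethoxy)phenyl in place of 5-chloro-2-methoxyphenyl on the cyclohexyl core gives a 1.1-fold higher number from compound 3 to compound 4 (0.05 log units; within the scatter), which agrees with the same change on the isopropyl core: the same change on two cores in this assay, a 1.0-fold lower number (0.01 log units; within the scatter) from compound 1 to compound 2 and a 1.1-fold higher number (0.05 log units; within the scatter) from compound 3 to compound 4, 1.2-fold (0.07 log units) apart, within the scatter of two such steps. Read the other way round, cyclohexyl in place of isopropyl gives a 1.2-fold higher number from compound 2 to compound 4 (0.08 log units; within the scatter), and this also agrees with its earlier counterpart: the same change on two cores in this assay, a 1.0-fold higher number (0.01 log units; within the scatter) from compound 1 to compound 3 and a 1.2-fold higher number (0.08 log units; within the scatter) from compound 2 to compound 4, 1.2-fold (0.07 log units) apart, within the scatter of two such steps. The two changes therefore carry from one core to the other only in the sense that neither produces a step beyond the scatter on either core; this does not show that a step of real size would carry over in the same way, and two cores are too few to support a rule for the wider series.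

The compounds shown leave open whether any change to this scaffold moves the number beyond the scatter, for example a carboxylic acid in place of the methyl ester, or an amine or a longer chain in place of the cyclohexyl or isopropyl group. They also leave open whether a change of that kind would give the same step on both cores.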